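Removing a Methyl From the Five-Membered Ring: Maximal Response Expected

A few compounds are considered here, and "the series" means these few. Any claim that something is new, unique, unknown or untested is made for them only; others in the source may bear on it.

Measured compounds:
Compound 1, `Cc1nc(-c2ccccc2NCC2=NCCN2)n(C)n1`, gives 0% in a functional assay with Alpha-1B adrenergic receptor (Homo sapiens) as the target, read by calcium flux; on this read-out higher numbers stand for larger maximal responses and lower numbers for smaller maximal responses.
Compound 2, `Cc1ccc(-c2ccccc2NCC2=NCCN2)n1C`, gives 0% in this assay.

Compound 2 stands level with compound 1 in this assay: both show no maximal response at the digits reported, and the two values lie within the usual scatter of each other, so no order between them can be read. Among the compounds with values here, no step between measured compounds is given beyond this pair, and the pair shows no change.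

The next compound, compound 3, `Cn1cccc1-c1ccccc1NCC1=NCCN1`, has not yet been measured in this assay. It differs from compound 2 in one place, (hydrogen in place of methyl on an aromatic carbon), on an aromatic carbon of a five-membered aromatic ring with one nitrogen, next to the ring nitrogen. Within the data shown here, nothing measured so far ties a methyl at that place to the read-out, since compound 1 and compound 2 both give no response.

For compound 3 the expectation is no step beyond the scatter, no change at the digits printed from compound 2 to compound 3 (within the scatter), because compound 2 gives 0%. Compound 3 is therefore estimated at 0%, with a range from 0% to 10%.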

Compound 3, largest response reached (reported as maximal response), in percent of the reference or control that the assay uses: 0%
Compound 3: middle estimate and measured number agree at the digits printed; low and high end bracket the measured number.
By their numbers in this assay, from the lowest: compounds 1, 2 and 3 (each within the scatter of the next).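

The removal of the methyl on an aromatic carbon of the five-membered aromatic ring with 1 nitrogen, next to the ring nitrogen, gives no change at the digits printed from compound 2 to compound 3 (within the scatter) in this assay. The absence of a response in compound 2 therefore does not depend on that methyl, as compound 3, with hydrogen at this place, also gives 0%. No information is available to explain this result.

The compounds shown leave open whether a different group at this place, such as an amine, a carboxylic acid or a longer chain, would give any response in this assay. They also leave open whether hydrogen in place of methyl would matter in a compound that does give a response, since a read-out that stays at nothing cannot show such a step here.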